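Ethoxy to Allyloxy on a Highly Soluble Core

The source may report more compounds than this note shows. Statements on the series, on what has been measured and on what is new or still open speak of the compounds shown alone.

Compound 2 `CCOc1ccc2c(NCCCN(C)C)ccnc2c1` carries an ethoxy group on the shared core. In a physicochemical assay for solubility (a lower number here means a less soluble compound, a higher number a more soluble compound), compound 2 gives > 10000 ug/mL, which is a limit of the assay rather than a number. Compound 1 `CN(C)CCCNc1ccnc2cc(OCc3ccc(F)cc3)ccc12` differs from compound 2 only in the group sitting on the saturated chain carbon bound to an oxygen on the aromatic ring. In this assay compound 1 gives > 10000 ug/mL, again a limit of the assay and not a number. Because both measured values sit at the limit of > 10000 ug/mL in this assay, at which 2 of the 2 values shown sit, the step that the two limits leave unreadable from compound 1 to compound 2 cannot be read in either direction.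

Compound 3 `C=CCOc1ccc2c(NCCCN(C)C)ccnc2c1` is the next compound to consider. It differs from compound 2 by vinyl in place of methyl on a saturated chain carbon bound to an oxygen on an aromatic ring. Among the compounds with values here, the only measured step that bears on this change, the one from compound 1 to compound 2, is unreadable, so it offers no size to carry over. Compound 3 is therefore expected to stay at the same limit, with a number no higher from compound 2 to compound 3 (the limit leaves the size open) meaning no step beyond the scatter. The estimate for compound 3 in this assay is 10000 ug/mL, with a range from 5000 ug/mL to 20000 ug/mL.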

Compound 3, solubility: > 10000 ug/mL
Compound 3 gave a limit, no number (the forecaster's own chance of this, stated with the estimate: 85%); the middle value lies on the limit itself.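

Compound 1, compound 2 and compound 3 all sit at the same limit of this assay, which is not a number, so no step among them can be read in either direction: the limit of > 10000 ug/mL in this assay, at which 3 of the 3 values shown sit.

The compounds shown leave open what number each would give past that limit, and whether ethoxy to allyloxy makes any difference in this assay.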